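Chloro for Methoxy on the Amide Aryl Ring

This account rests on a few compounds, and the source may have more. Where it says the series, first, only, none or still open, it means among the compounds named here.

Measured compounds:
Compound 1, `O=C(Nc1cc(Sc2ncn[nH]2)c(O)c2ccccc12)c1cccc([N+](=O)[O-])c1`, gives 48000 nM in a functional assay on MDA-MB-231 cells (Homo sapiens) for antiproliferative activity, read by MTT assay, with a stated time of 48 h; on this read-out higher numbers stand for weaker inhibition and lower numbers for stronger inhibition.
Compound 2, `O=C(Nc1cc(Sc2ncnc3nc[nH]c23)c(O)c2ccccc12)c1ccc(Cl)cc1`, gives 23000 nM in this assay.
Compound 3, `COc1ccc(C(=O)Nc2cc(Sc3ncn[nH]3)c(O)c3ccccc23)cc1`, gives > 100000 nM in this assay.

The reading for compound 3 is a limit of the assay and not a number. Among the three values shown it sits at the limit of > 100000 nM in this assay, at which 1 of the 3 values shown sits. Compound 4, `O=C(Nc1cc(Sc2ncn[nH]2)c(O)c2ccccc12)c1ccc(Cl)cc1`, differs from compound 3 by chloro in place of methoxy on an aromatic carbon.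

Going by the values given here, only one measured step bears on this change, and it does so loosely: an at least 2.0-fold higher number from compound 1 to compound 3 (0.31 log units; beyond the scatter) shows that replacing the 3-nitrophenyl of compound 1 with the 4-methoxyphenyl of compound 3 moved the number toward the limit. Among the compounds with values here, compound 2 carries the same 4-chlorophenyl as compound 4 on a different core and gives a number rather than a limit; no step between compound 2 and compound 4 can be given.

Compound 4 is therefore expected to give a measurable number, 40000 nM, with a range from 15000 nM to 150000 nM, which would amount to an at least 2.5-fold lower number from compound 3 to compound 4 (0.39 log units; beyond the scatter).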

Compound 4, half-maximal inhibitory concentration: 25700 nM
Compound 4: the middle estimate sits 1.6-fold (0.19 log units) above what was measured, and the stated range covers the measured number.
By their numbers in this assay, from the lowest: compounds 2, 4 and 1 (each within the scatter of the next, the first and the last beyond it). At a limit, above all of these: compound 3.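

Compound 3 remains a limit of the assay and not a number: the limit of > 100000 nM in this assay, at which 1 of the 4 values shown sits. At this position of the amide aryl ring, 4-chlorophenyl in place of 4-methoxyphenyl gives a measurable reading in this assay, with an at least 3.8-fold lower number from compound 3 to compound 4 (0.59 log units; beyond the scatter), so the change is a real one on the shared core. Exchanging the group on the sulfur leaves the 4-chlorophenyl amides within the scatter, with a 1.1-fold higher number from compound 2 to compound 4 (0.05 log units; within the scatter), and 4-chlorophenyl in place of 3-nitrophenyl stays within it too, with a 1.9-fold lower number from compound 1 to compound 4 (0.27 log units; within the scatter).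

From the compounds shown here alone, whether a plain phenyl, a 4-fluorophenyl or a 4-aminophenyl would read like compound 4 or like compound 3 stays open. Also open, going by these compounds, is whether 4-methoxyphenyl on the core of compound 2 would give a limit as well.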